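The source may report more compounds than this note shows. Statements on the series, on what has been measured and on what is new or still open speak of the compounds shown alone.

Measured in a functional assay on RKO cells (Homo sapiens) for cytotoxicity, read by resazurin assay, with a stated time of 72 h; on this read-out higher numbers stand for weaker inhibition and lower numbers for stronger inhibition:
- compound 1 `Brc1ccc(Nc2nc(-n3cnc4ccccc43)cs2)cc1`: > 100000 nM (a limit of the assay, not a number)
- compound 2 `COc1ccc(Nc2nc(-n3ccnc3C)cs2)cc1`: 1600 nM
- compound 3 `Cc1nc(C)c(-c2csc(Nc3ccc(Br)cc3)n2)s1`: 700 nM

Only two of these three results are actual numbers. Of those two, compound 3 holds the lower, and compound 2 stands highest at 1600 nM. The gap between them lies beyond the usual scatter, so compound 2 is the weaker of the pair in this assay.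

The next compound is compound 4 `Cc1ccc(Nc2nc(-n3ccnc3C)cs2)cc1`, which carries methyl in place of methoxy on an aromatic carbon, para to a large group, and keeps the rest of compound 2 unchanged: methyl in place of methoxy on an aromatic carbon.

Among the measured compounds shown here, no measured pair shows this change, so the expectation starts from compound 2 at 1600 nM. Little movement is expected, with no shift in either direction beyond the scatter. The expected step is a 1.1-fold lower number from compound 2 to compound 4 (0.03 log units; within the scatter). For compound 4 the estimated value is 1500 nM, with an expected range from 500 nM to 5000 nM.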

Compound 4, half-maximal inhibitory concentration: 450 nM
For compound 4 the middle estimate is 3.3-fold (0.52 log units) above the measured one; measured number below the stated range.
By their numbers in this assay, from the lowest: compounds 4 and 3 (each within the scatter of the next); then compound 2. At a limit, above all of these: compound 1.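

In this assay, among the compounds shown here, the exchange of methoxy for methyl on an aromatic carbon, para to a large group, gives a 3.6-fold lower number from compound 2 to compound 4 (0.55 log units; beyond the scatter) and provides the first reading between two compounds that differ in one place. It shows that this position responds to the change, with the lower number on the side of methyl, the smaller group with no hydrogen-bond acceptor. What lies behind the step cannot be said from the data given here.

Going by these compounds, a single pair cannot show whether the step follows from the loss of the oxygen or from some other difference between the two groups, and how an amine, a hydroxyl or a longer chain such as ethyl would read at this position remains open. On these data alone, whether the same exchange gives a similar step on the cores of compound 1 and compound 3 also remains unknown.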